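A few compounds are considered here, and "the series" means these few. Any claim that something is new, unique, unknown or untested is made for them only; others in the source may bear on it.

The compounds share one core, which carries a chloro group and an amide, and they differ in the group on the ring nitrogen and in the aryl of the amide. In an assay on CHO cells for displacement of a labelled ligand from adenosine receptor A1 (Homo sapiens), read by scintillation counting, with a stated time of 3 h (a higher number here means a weaker inhibitor, a lower number a stronger inhibitor), compound 1 `Cc1ccc(C(=O)Nc2nc(Cl)c3cn(C)nc3n2)cc1` gives > 100000 nM, which is a limit of the assay and not a number (the limit of > 100000 nM in this assay, at which 1 of the 3 values shown sits). Compound 2 `Cc1ccc(C(=O)Nc2nc(Cl)c3cn(CC(C)(C)C)nc3n2)cc1` gives 11100 nM in this assay. Compound 3 `CC(C)n1cc2c(Cl)nc(NC(=O)c3ccccc3)nc2n1` gives 19600 nM in this assay; this is the higher of the two numbers shown, but the gap to its nearest neighbour, compound 2, lies within the scatter. Compound 4 `Cc1ccc(C(=O)Nc2nc(Cl)c3cn(C(C)C)nc3n2)cc1` has not yet been measured and differs from compound 3 by methyl in place of hydrogen on an aromatic carbon. Among the measured compounds shown here, the only measured step, an at least 9.0-fold lower number from compound 1 to compound 2 (0.95 log units; beyond the scatter), concerns the group on the ring nitrogen and not the aryl of the amide, so it bears on this change only indirectly. Compound 2 carries the 4-methylphenyl and compound 3 the phenyl, yet they differ on the ring nitrogen as well, so their two values show only that the two lie within the scatter of each other. For compound 4 the step of a 1.3-fold lower number from compound 3 to compound 4 (0.12 log units; within the scatter) is therefore expected to stay within the scatter, in no clear direction. Compound 4 is estimated to give 15000 nM, with a range from 6000 nM to 45000 nM.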

Compound 4, inhibition constant: 4100 nM
Compound 4: middle estimate off by 3.7-fold (0.56 log units), on the high side; the whole stated range lies above it.
By their numbers in this assay, from the lowest: compound 4; then compounds 2 and 3 (each within the scatter of the next). At a limit, above all of these: compound 1.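

Among the compounds shown here, the step of a 4.8-fold lower number from compound 3 to compound 4 (0.68 log units; beyond the scatter) is the first reading of this change alone: with isopropyl held on the ring nitrogen, going from phenyl to 4-methylphenyl moves the number beyond the scatter in this assay, which no earlier pair could show. With the 4-methylphenyl held fixed, the step of a 2.7-fold lower number from compound 2 to compound 4 (0.43 log units; beyond the scatter) shows that isopropyl on the ring nitrogen gives a lower number than neopentyl. The step of an at least 24-fold lower number from compound 1 to compound 4 (1.38 log units; beyond the scatter) starts from a limit of the assay and not a number: the limit of > 100000 nM in this assay, at which 1 of the 4 values shown sits.

Going by these compounds, whether the methyl has the same effect with neopentyl or methyl on the ring nitrogen remains open. So does how a methoxy group, a chloro group or a carboxylic acid in that same place on the aryl would compare with methyl.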